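Benzyl to Dimethylaminophenyl: Cell Tolerance Outlook

The source may report more compounds than this note shows. Statements on the series, on what has been measured and on what is new or still open speak of the compounds shown alone.

Compound 1, `CN1CCN(CCNCc2cn(-c3ccc(F)cc3F)nc2Cc2ccccc2)CC1`, in an ADME assay on Huh-7 cells (Homo sapiens) for cytotoxicity; a higher number here means that more compound is tolerated, a lower number that less compound is tolerated: > 20000 nM, a limit of the assay.
Compound 2, `Cc1ccccc1-c1nn(-c2ccccc2Cl)cc1CNCCN1CCN(C)CC1`, in this assay: > 20000 nM, a limit of the assay.
Compound 3, `CCN(CC)CCCNCc1cn(-c2ccc(F)cc2F)nc1-c1ccccc1C`, in this assay: > 20000 nM, a limit of the assay.

Each of the three measured compounds gives only a limit in this assay, not a number. Compound 1 therefore stands at the limit of > 20000 nM in this assay, at which 3 of the 3 values shown sit, side by side with the two other compounds, and none of the three can be told apart from the others on this read-out. Among the measured compounds shown here, no pair of measured compounds differs in a single place, so there is no measured step to build on.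

Compound 4, `CN1CCN(CCNCc2cn(-c3ccc(F)cc3F)nc2-c2ccc(N(C)C)cc2)CC1`, is the compound still to be measured. It differs from compound 1 in one place: 4-(dimethylamino)phenyl in place of benzyl on an aromatic carbon. The three measured compounds differ from one another in several places, yet all sit at the same limit, which gives no sign that the aromatic groups on the shared core move this read-out.

For compound 4 the expectation is a step that the limit leaves unreadable from compound 1 to compound 4 of no size beyond the scatter. Compound 4 is expected to give 25000 nM in this assay, with a range from 10000 nM to 60000 nM. The assay is expected to report only a limit again, because compound 1 gives > 20000 nM.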

Compound 4, half-maximal cytotoxic concentration: > 20000 nM
Compound 4: only a limit was reported; the forecaster's own chance of this, stated with the estimate: 80%; the middle value lies beyond the limit too.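

Compound 1 and compound 4 both end at a limit rather than a number in this assay, so no step from benzyl to 4-(dimethylamino)phenyl can be read: the limit of > 20000 nM in this assay, at which 4 of the 4 values shown sit.

The compounds shown leave open the concentration at which any of them reaches half-maximal cytotoxicity, and whether 4-(dimethylamino)phenyl in place of benzyl makes any difference to it.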